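The source may hold more compounds than are shown below. What is called first, only, known or untested is meant among the compounds shown, and "the series" means these compounds.

Of the compounds shown here, three built on one shared core have so far been measured in an assay on isolated protein for antagonist activity at transient receptor potential cation channel subfamily V member 1 (Homo sapiens); on this read-out lower numbers stand for stronger inhibition and higher numbers for weaker inhibition. Compound 1 `O=C(Nc1ccccc1F)N1CCN(c2ccnc(Cl)n2)CC1` gives 787 nM in this assay. Compound 2 `O=C(Nc1cccc(F)c1)N1CCN(c2ccnc(Cl)n2)CC1` gives 952 nM in this assay. The two cores differ as follows: 3-fluorophenyl in place of 2-fluorophenyl on an amide-type nitrogen, and the step of a 1.2-fold higher number from compound 1 to compound 2 (0.08 log units; within the scatter). Compound 3 `O=C(Nc1ccccc1C(F)(F)F)N1CCN(c2ccnc(Cl)n2)CC1` gives 136 nM in this assay, and compound 3 stands at the lowest number of the three. Compound 3 differs from compound 1 as follows: trifluoromethyl in place of fluoro on an aromatic carbon, and this change made the step of a 5.8-fold lower number from compound 1 to compound 3 (0.76 log units; beyond the scatter).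

Compound 4 `O=C(Nc1cccc(C(F)(F)F)c1)N1CCN(c2ccnc(Cl)n2)CC1` has not yet been measured. It differs from compound 2 as follows: trifluoromethyl in place of fluoro on an aromatic carbon. For the measured compounds named here, this is the same kind of change as the one from compound 1 to compound 3, but the place is not the same: in compound 3 the trifluoromethyl sits ortho to a large group, while in compound 4 it sits meta to a large group. Whether the step keeps its size when the place shifts in this way is not known from these three compounds.

Resting on the step from compound 1 to compound 3, a lowering of similar though perhaps smaller size is expected from compound 2 to compound 4, estimated as a 3.8-fold lower number from compound 2 to compound 4 (0.58 log units; beyond the scatter). For compound 4 the estimated value in this assay is 250 nM, with an expected range from 80 nM to 700 nM.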

Compound 4, half-maximal inhibitory concentration: 543 nM
The estimate for compound 4 lay 2.2-fold (0.34 log units) below the measured number; the measured number falls inside the stated range.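

In this assay, placing trifluoromethyl instead of fluoro on the aromatic carbon meta to a large group gave a 1.8-fold lower number from compound 2 to compound 4 (0.24 log units; within the scatter), a step that cannot be told apart from the scatter of repeated measurements. For the compounds shown here, the exchange therefore cannot be carried from one core to the other at a fixed size, as the two steps do not agree: the same change on two cores in this assay, a 5.8-fold lower number (0.76 log units; beyond the scatter) from compound 1 to compound 3 and a 1.8-fold lower number (0.24 log units; within the scatter) from compound 2 to compound 4, 3.3-fold (0.52 log units) apart, beyond the scatter of two such steps This shows that the clear step seen on the core of compound 1 does not predict a clear step on the core of compound 2, but it does not show why the steps differ, and with only one pair of compounds behind each step, it gives no general rule for this series.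

The compounds shown leave open how a nitrile, a methoxy group or an amine on the same aromatic carbon would read in this assay, and whether other places on that ring would give a step closer to the larger or the smaller one. They also leave open whether the gap between the two steps would persist if the chloro group of the shared core gave way to an amine or a longer chain.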